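The source may hold more compounds than are shown below. What is called first, only, known or untested is meant among the compounds shown, and "the series" means these compounds.

Measured so far, all in a functional assay on HEK293 cells (Homo sapiens) for cytotoxicity; on this read-out lower numbers stand for higher toxicity in this test and higher numbers for lower toxicity in this test (each value is a limit of the test):

Compound 1 (`COc1ccc([C@H]2CC(=O)N(C(C)=O)C2)cc1OC1CCCC1`) gives > 10000 nM
Compound 2 (`COc1ccc([C@H]2CC(=O)N(c3cccc(O)c3)C2)cc1OC1CCCC1`) gives > 10000 nM
Compound 3 (`COc1ccc([C@H]2CC(=O)N(c3cccc(C(F)(F)F)c3)C2)cc1OC1CCCC1`) gives > 10000 nM

Compound 3 sits at the limit of > 10000 nM in this assay, at which 3 of the 3 values shown sit, and so has only a limit, not a number of its own. Compound 4 (`COc1ccc([C@H]2CC(=O)N(c3cccc(S(C)(=O)=O)c3)C2)cc1OC1CCCC1`) differs from it in one place, with methylsulfonyl in place of trifluoromethyl on an aromatic carbon. For the measured compounds named here, three measured steps bear on this change. The swap on an aromatic carbon (a step that the two limits leave unreadable from compound 2 to compound 3) comes closest. The two swaps on the amide-type nitrogen (a step that the two limits leave unreadable from compound 1 to compound 2) and (a step that the two limits leave unreadable from compound 1 to compound 3) are less close. None of the three has a readable size, so none offers a direction to carry over. Compound 3 gives > 10000 nM as a limit, and compound 4 is expected to stay at that same limit. The expected step (a step that the limit leaves unreadable from compound 3 to compound 4) in this assay therefore comes with no expected direction. The estimate for compound 4 is 20000 nM (expected range 10000 nM to 60000 nM).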

Compound 4, half-maximal cytotoxic concentration: > 10000 nM
Compound 4 was reported as a limit (the forecaster's own chance of this, stated with the estimate: 90%); the middle value is on the limit's open side.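

Compound 4, like compound 1, compound 2 and compound 3, has only a limit in this assay, so its steps to those three cannot be read: the limit of > 10000 nM in this assay, at which 4 of the 4 values shown sit.

The compounds shown leave open the concentration at which any of them reaches half-maximal cytotoxicity, and whether the swapped groups change it.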